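Notes on the amide-nitrogen aryl swap in this series

The source may report more compounds than this note shows. Statements on the series, on what has been measured and on what is new or still open speak of the compounds shown alone.

Compound 1 `Cn1cc(C(=O)O)c2ccc(N3C(=O)CCc4cc(OCc5c(-c6c(Cl)cccc6Cl)noc5C5CC5)ccc43)cc21` and compound 2 `O=C1CCc2cc(OCc3c(-c4c(Cl)cccc4Cl)noc3C3CC3)ccc2N1c1ncc(O)cc1F` share a core and differ only in the aryl group carried by the ring amide nitrogen. In an assay on isolated protein for agonist activity at Bile acid receptor (Homo sapiens), read by AlphaScreen, with a stated time of 1 h (a lower number here means a smaller maximal response, a higher number a larger maximal response), compound 1 gives > 100%, which is a limit of the assay rather than a number. In this assay compound 2 likewise gives > 100%, again a limit and not a number. Among the compounds with values here, compound 2 therefore stands where every value so far stands, namely at the limit (the limit of > 100% in this assay, at which 2 of the 2 values shown sit). Within the data shown here, no step between two measured compounds is available. For the unmeasured compound only an expectation can be framed.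

Compound 3 `O=C(O)c1ccc(N2C(=O)CCc3cc(OCc4c(-c5c(Cl)cccc5Cl)noc4C4CC4)ccc32)nc1` carries the change (a group of 9 heavy atoms (6 carbon, 1 nitrogen, 2 oxygen; one six-membered aromatic ring with 1 hetero atom) in place of a group of 8 heavy atoms (5 carbon, 1 nitrogen, 1 oxygen, 1 fluorine; one six-membered aromatic ring with 1 hetero atom), on an amide-type nitrogen in a ring). Because both known values sit at the limit (the limit of > 100% in this assay, at which 2 of the 2 values shown sit), no step beyond the scatter is anticipated for compound 3 in this assay. The expected step is a number no higher from compound 2 to compound 3 (the limit leaves the size open), which is meant as no real change. Compound 3 is estimated at 100% in this assay, within a range of 80% to 115%, with a fair chance that only a limit is again reported.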

Compound 3, largest response reached (Emax), in percent of the reference or control that the assay uses: > 100%
Compound 3 ended at the assay's limit; the forecaster's own chance of this, stated with the estimate: 55%; the middle value lies on the limit itself.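

No step can be read between compound 2 and compound 3 in this assay, since the values of both are limits rather than numbers: the limit of > 100% in this assay, at which 3 of the 3 values shown sit.

The compounds shown leave open whether the aryl groups on the ring amide nitrogen differ at all in largest response reached.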